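A few compounds are considered here, and "the series" means these few. Any claim that something is new, unique, unknown or untested is made for them only; others in the source may bear on it.

Series values in a physicochemical assay for solubility, in phosphate buffer, measured as kinetic solubility, at pH 7.4, tested at 250 uM; on this read-out lower numbers stand for lower solubility and higher numbers for higher solubility:

- compound 1 `CN(C)S(=O)(=O)c1cc(C(=O)O)ccc1NCCCC(F)(F)F`: 245000 nM
- compound 2 `CN(C)S(=O)(=O)c1cc(C(=O)O)ccc1NCCCCCC(F)(F)F`: 249000 nM
- compound 3 `COCCNc1ccc(C(=O)O)cc1S(=O)(=O)N(C)C`: not yet measured

Compound 2 stands at 249000 nM in this assay, within the scatter of compound 1 at 245000 nM. Both numbers lie close to the concentration tested, which leaves little room for a higher reading.

The next change is methoxy in place of 4,4,4-trifluorobutyl on a saturated chain carbon, two bonds along the chain from a nitrogen on an aromatic ring. In words, it is methoxy in place of 4,4,4-trifluorobutyl on a saturated chain carbon, two bonds along the chain from a nitrogen on an aromatic ring.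

For the measured compounds named here, only one measured step bears on this change, and only indirectly. The a 1.0-fold higher number from compound 1 to compound 2 (0.01 log units; within the scatter) is within the scatter, and it alters the fluorinated chain while keeping it fluorinated. Going by the values given here, no measured compound carries methoxy, so the effect of this group is untested.

With only a 1.0-fold higher number from compound 1 to compound 2 (0.01 log units; within the scatter) as a guide, no step beyond the scatter is expected. The estimated 1.0-fold lower number from compound 2 to compound 3 (0.02 log units; within the scatter) is therefore small. Compound 3 is expected at about 240000 nM, with an estimated range of 170000 nM to 260000 nM.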

Compound 3, solubility: 237000 nM
Beside the measured number, compound 3's estimate is 1.0-fold (0.01 log units) above it; measured number inside the range.
By their numbers in this assay, from the lowest: compounds 3, 1 and 2 (each within the scatter of the next).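

Swapping the fluorinated chain for methoxy on a saturated chain carbon, two bonds along the chain from a nitrogen on an aromatic ring, gives the step (a 1.1-fold lower number from compound 2 to compound 3 (0.02 log units; within the scatter)) in this assay, and the comparison with the shorter fluorinated chain gives (a 1.0-fold lower number from compound 1 to compound 3 (0.01 log units; within the scatter)). Both steps lie within the scatter, so the flat picture now extends beyond chains that stay fluorinated to a much smaller group that has no fluorine and brings a hydrogen-bond acceptor. All three readings sit close to the concentration tested, and nothing on hand explains why this change leaves the read-out within the scatter.

With all three readings so close to the concentration tested, this read-out has little room to register any rise, so only a clearly lower reading would separate a new group from these three. As far as these compounds go, whether this position tolerates everything remains open: a phenyl ring or a tertiary amine at the end of the chain would test the flat picture with groups of a different kind, and a longer chain ending in methoxy would show whether the result holds as the chain grows.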